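Isatin series: benzyl-type substituents on the ring nitrogen

The compounds below may be only part of what the source reports. "The series", "measured", "known", "first", "only" and "open" are said of these compounds alone.

Measured compounds:
compound 1, `C=CCN1C(=O)C(=O)c2cc(-c3ccc(OC)cc3)ccc21`, 7090 nM
compound 2, `COc1ccc(CN2C(=O)C(=O)c3cc(-c4ccc(OC)cc4)ccc32)cc1`, 50 nM
compound 3, `COc1ccc(-c2ccc3c(c2)C(=O)C(=O)N3Cc2cccc(OC)c2)cc1`, 700 nM

In a functional assay on HepG2 cells (Homo sapiens) for antiproliferative activity, read by MTT assay, with a stated time of 48 h (on this read-out higher numbers stand for weaker inhibition and lower numbers for stronger inhibition), compound 1 gives the highest number of the three; compound 3 is nearest with a lower value, and compound 2 is furthest with a still lower value. Compound 4, `COc1ccc(-c2ccc3c(c2)C(=O)C(=O)N3Cc2ccc(C(F)(F)F)cc2)cc1`, has not yet been measured. It differs from compound 1 in one place: 4-(trifluoromethyl)phenyl in place of vinyl on a saturated chain carbon bound to an amide-type nitrogen in a ring.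

Among the compounds with values here, two measured steps bear on this change, both starting from compound 1 and both placing a methoxyphenyl on the same saturated chain carbon bound to the amide-type nitrogen. The step of a 140-fold lower number from compound 1 to compound 2 (2.15 log units; beyond the scatter) was large, and the step of a 10-fold lower number from compound 1 to compound 3 (1.01 log units; beyond the scatter) was also large but smaller; the step of a 14-fold higher number from compound 2 to compound 3 (1.15 log units; beyond the scatter) shows how much the pattern of substitution on the entering phenyl matters. Compound 4 carries a 4-(trifluoromethyl)phenyl, a substituted phenyl of the same general kind as in compound 2, so a large step downward beyond the scatter is expected in this assay, though whether the trifluoromethyl matches the methoxy of compound 2 cannot be read from these data.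

Compound 4 is therefore estimated at 150 nM, between 40 nM and 600 nM, which would mean an expected step of a 47-fold lower number from compound 1 to compound 4 (1.67 log units; beyond the scatter).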

Compound 4, half-maximal inhibitory concentration: 380 nM
Estimate against measurement, compound 4: 2.5-fold (0.40 log units) below; the measured number falls inside the stated range.
By their numbers in this assay, from the lowest: compound 2; then compounds 4 and 3 (each within the scatter of the next); then compound 1.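

In this assay, the change recorded as a 19-fold lower number from compound 1 to compound 4 (1.27 log units; beyond the scatter) shows that the large drop on replacing vinyl at this saturated chain carbon is not confined to the two methoxyphenyl groups, since it also appears with 4-(trifluoromethyl)phenyl. The step recorded as a 7.6-fold higher number from compound 2 to compound 4 (0.88 log units; beyond the scatter) isolates the substituent on the entering phenyl: trifluoromethyl in place of methoxy on an aromatic carbon gives up part of the gain, though the step is modest. Within the data shown here, compound 3 and compound 4 are not separated, as a 1.8-fold lower number from compound 3 to compound 4 (0.27 log units; within the scatter) lies within the scatter, so compound 2 remains the only compound of the four whose number stands apart from all the others on the low side.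

Still open, as far as these compounds go, is whether an unsubstituted phenyl, a phenyl carrying an amine or a carboxylic acid, or a longer chain bearing the 4-methoxyphenyl would hold the number of compound 2 or lose it. No measurement shown here offers an explanation for the differences among these groups.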